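The source may hold more compounds than are shown below. What is called first, only, known or untested is meant among the compounds shown, and "the series" means these compounds.

Working notes on a three-compound series around a shared core. Compound 1 `COc1ccc(-c2cn3ccnc3c(-c3ccc4ncn(C5CCCCC5)c4c3)n2)cc1` is the reference; in a functional assay on Hs-578T cells (Homo sapiens) for inhibition, read by sulforhodamine B assay, with a stated time of 48 h, tested at 10 uM (a higher number here means more inhibition at the concentration tested (going by the name of the read-out), a lower number less inhibition), compound 1 gives 80%. Compound 2 `O=Cc1ccc(-c2cn3ccnc3c(-c3ccc4ncn(C5CCCCC5)c4c3)n2)cc1` carries a formyl in place of the methoxy, and in this assay compound 2 gives 45.5%, so the change is a number 34.5 percentage points lower from compound 1 to compound 2 (beyond the scatter). Compound 3 `Clc1ccc(-c2cn3ccnc3c(-c3ccc4ncn(C5CCCCC5)c4c3)n2)cc1` carries a chloro at the same aromatic carbon; in this assay compound 3 gives 6.35%. The step is a number 73.7 percentage points lower from compound 1 to compound 3 (beyond the scatter), and against compound 2 it is a number 39.2 percentage points lower from compound 2 to compound 3 (beyond the scatter). Compound 3 thus stands lowest of the three values, with compound 2 nearest and compound 1 furthest from it, both beyond the scatter.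

Compound 4 `Fc1ccccc1-c1cn2ccnc2c(-c2ccc3ncn(C4CCCCC4)c3c2)n1` is not yet measured. Relative to compound 3 the change is 2-fluorophenyl in place of 4-chlorophenyl on an aromatic carbon. Within the data shown here, none of the measured steps bears on this directly: all three vary the group on the same ring and the same place, and none brings in fluorine or a 2-substituted phenyl. Among the measured compounds shown here, the only relevant reading is that the chloro-bearing compound 3 gives the lowest number in this assay, so a move away from 4-chlorophenyl is expected to give a step in this assay of a number 18.7 percentage points higher from compound 3 to compound 4 (beyond the scatter), upward but of uncertain size. Compound 4 is therefore estimated at 25%, within 0% to 60%.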

Compound 4, a percentage reported as inhibition, at one concentration (the size of the read-out at that concentration, not a potency): 5.26%
Beside the measured number, compound 4's estimate is 19.7 percentage points above it; low and high end bracket the measured number.
By their numbers in this assay, from the lowest: compounds 4 and 3 (each within the scatter of the next); then compound 2; then compound 1.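

In this assay, replacing 4-chlorophenyl with 2-fluorophenyl gives a number 1.1 percentage points lower from compound 3 to compound 4 (within the scatter), so at this position on the shared core the two halogen-bearing phenyl groups cannot be told apart, even though both the halogen and its place on the phenyl differ. The steps from the other two compounds remain large, a number 40.2 percentage points lower from compound 2 to compound 4 (beyond the scatter) and a number 74.7 percentage points lower from compound 1 to compound 4 (beyond the scatter), which places compound 4 with compound 3 at the low end rather than adding a new level, and leaves the two halogen-bearing compounds apart from both the 4-formylphenyl and the 4-methoxyphenyl compounds. No measurement shown here accounts for this grouping.

Because the halogen and its place on the phenyl change together in the step between compound 3 and compound 4, the compounds shown leave open whether either change alone would move the number, or whether the two effects merely offset each other. Also open is how a phenyl carrying an amine or a carboxylic acid in place of the methoxy of compound 1 would compare, since only four groups at this position are shown.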